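Iodo cinnamamides: from 2-chlorophenyl to 4-methylphenyl

A few compounds are considered here, and "the series" means these few. Any claim that something is new, unique, unknown or untested is made for them only; others in the source may bear on it.

- compound 1 `Cc1ccc(/C=C/C(=O)Nc2ccc(Br)cc2C(N)=O)cc1` gives 45.9%
- compound 2 `NC(=O)c1cc(I)ccc1NC(=O)/C=C/c1ccccc1` gives 74.5%
- compound 3 `NC(=O)c1cc(I)ccc1NC(=O)/C=C/c1ccccc1Cl` gives 74.1%
- compound 4 `Cc1ccc(/C=C/C(=O)Nc2ccc(I)cc2C(N)=O)cc1` is not yet measured

In a functional assay on K562 cells (Homo sapiens) for antiproliferative activity, read by trypan blue exclusion, with a stated time of 48 h, tested at 10 uM (a higher number here means more inhibition of growth at the concentration tested, a lower number less inhibition of growth), compound 3 gives 74.1% within the scatter of compound 2 and well beyond the scatter of compound 1. The next change is 4-methylphenyl in place of 2-chlorophenyl on a double-bonded chain carbon bound to a double-bonded chain carbon with 4-methylphenyl in place of 2-chlorophenyl on a double-bonded chain carbon bound to a double-bonded chain carbon. Within the data shown here, the one measured step, a number 0.4 percentage points lower from compound 2 to compound 3 (within the scatter) stayed within the scatter. Among the measured compounds shown here, compound 1, the only measured compound with 4-methylphenyl, gives 45.9% and pulls the expectation down somewhat. The data do not separate that group from the rest of compound 1. A modest drop is expected, an estimated a number 7.1 percentage points lower from compound 3 to compound 4 (within the scatter) within the scatter. Compound 4 is estimated at 67% with an expected range of 50% to 80% in this assay.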

Compound 4, percent growth inhibition at one concentration: 26.3%
Compound 4: middle estimate off by 40.7 percentage points, on the high side; the whole stated range lies above it.
By their numbers in this assay, from the lowest: compound 4; then compound 1; then compounds 3 and 2 (each within the scatter of the next).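

Substitution on this aromatic ring is not silent: methyl in place of hydrogen gives a number 48.2 percentage points lower from compound 2 to compound 4 (beyond the scatter) and 4-methylphenyl in place of 2-chlorophenyl gives a number 47.8 percentage points lower from compound 3 to compound 4 (beyond the scatter) in this assay so the flat result for chloro in compound 3 does not extend to every group here. With 4-methylphenyl held constant, iodo in place of bromo gives a number 19.6 percentage points lower from compound 1 to compound 4 (beyond the scatter) and the halogen also matters in this series. Nothing available explains either drop.

Still open, going by these compounds, is whether the loss follows the methyl group or the ring position it occupies. A 2-methylphenyl or 4-chlorophenyl at this place would separate the two.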